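The source may report more compounds than this note shows. Statements on the series, on what has been measured and on what is new or still open speak of the compounds shown alone.

The measured compounds:
Compound 1, `CCOc1cccc2cc(-c3ccc([N+](=O)[O-])cc3)c(=O)oc12`: in an assay on CHO cells for displacement of a labelled ligand from adenosine receptor A2b (Homo sapiens), read by radioligand binding (on this read-out higher numbers stand for weaker inhibition and lower numbers for stronger inhibition), compound 1 gives > 30000 nM, a limit of the assay.
Compound 2, `Cc1ccc(-c2cc3cccc(C)c3oc2=O)cc1`: in this assay compound 2 gives > 30000 nM, a limit of the assay.
Compound 3, `Cc1cccc2cc(-c3ccc([N+](=O)[O-])cc3)c(=O)oc12`: in this assay compound 3 gives > 30000 nM, a limit of the assay.

Compound 3 thus stands where every value here stands, at the limit of > 30000 nM in this assay, at which 3 of the 3 values shown sit. The change to compound 4, `COc1cccc2cc(-c3ccc([N+](=O)[O-])cc3)c(=O)oc12`, is methoxy in place of methyl on an aromatic carbon. Two measured steps end at compound 3 and could bear on it: a step that the two limits leave unreadable from compound 1 to compound 3 and a step that the two limits leave unreadable from compound 2 to compound 3 are both unreadable, as both of their ends are limits. No measured step therefore sets a size in this assay for this change, and nothing among these compounds points to a gain beyond the scatter. Compound 4 is expected to stay at the limit, estimated at 60000 nM within 25000 nM to 200000 nM. The step this estimate implies is expected to be a step that the limit leaves unreadable from compound 3 to compound 4.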

Compound 4, inhibition constant: > 30000 nM
Compound 4 ended at the assay's limit (the forecaster's own chance of this, stated with the estimate: 85%); the middle value does not contradict the limit.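

The steps from compound 3 to compound 4 and from compound 1 to compound 4 cannot be read, since both ends of each are limits: the limit of > 30000 nM in this assay, at which 4 of the 4 values shown sit.

The compounds shown leave open what size any of these changes has, and whether any change to the shared core would bring a value off the limit.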